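This account rests on a few compounds, and the source may have more. Where it says the series, first, only, none or still open, it means among the compounds named here.

Compound 1 `Cc1ccc(-c2csc(N3N=C(c4ccc(C)s4)CC3c3ccc(F)cc3)n2)cc1` is the starting point of this account. In a functional assay on A549 cells (Homo sapiens) for antiproliferative activity, read by XTT assay, with a stated time of 24 h (a lower number here means a stronger inhibitor, a higher number a weaker inhibitor), compound 1 gives only a limit, > 500 ug/mL, and no number. Compound 2 `Cc1ccc(-c2csc(N3N=C(c4ccc(Cl)s4)CC3c3ccc(F)cc3)n2)cc1` differs from it by chloro in place of methyl on an aromatic carbon. In this assay compound 2 also gives only a limit, > 500 ug/mL. Compound 3 `COc1ccc(-c2csc(N3N=C(c4ccc(Cl)s4)CC3c3ccc(F)cc3)n2)cc1` carries methoxy in place of methyl on an aromatic carbon. For compound 3 this assay likewise reports a limit, > 500 ug/mL. The step that the two limits leave unreadable from compound 1 to compound 2 and the step that the two limits leave unreadable from compound 2 to compound 3 therefore cannot be read in size, because of the limit of > 500 ug/mL in this assay, at which 3 of the 3 values shown sit.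

Compound 4 `Cc1ccc(C2=NN(c3nc(-c4ccc(Br)cc4)cs3)C(c3ccc(F)cc3)C2)s1` is the compound still to be measured. Its change from compound 1 is bromo in place of methyl on an aromatic carbon. Of the measured steps, only those leaving compound 1 and compound 2 touch the same six-membered ring, and neither gives a readable size. Among the measured compounds shown here, no step points in any direction beyond the scatter, so no shift of measurable size is expected for compound 4, a step that the limit leaves unreadable from compound 1 to compound 4. Compound 4 is estimated at 600 ug/mL, within 250 ug/mL to 1500 ug/mL, most likely reported again as a limit.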

Compound 4, half-maximal inhibitory concentration: > 500 ug/mL
Compound 4 was reported as a limit (the forecaster's own chance of this, stated with the estimate: 80%); the middle value does not contradict the limit.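

No new step can be read, because compound 4, like compound 1, is reported only as a limit in this assay: the limit of > 500 ug/mL in this assay, at which 4 of the 4 values shown sit.

The compounds shown leave open how the methyl, chloro, methoxy and bromo groups compare, since none has a measured number in this assay.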